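Swapping a phenyl for an isobutyl on a pyranoside-like core

The source may report more compounds than this note shows. Statements on the series, on what has been measured and on what is new or still open speak of the compounds shown alone.

Measured compounds:
- compound 1, `c1ccc(COC[C@H]2OCC[C@@H](OCc3ccccc3)[C@@H]2OCc2ccccc2)cc1`: 39300 nM
- compound 2, `O[C@@H]1[C@@H](OCc2ccccc2)[C@H](OCc2ccccc2)[C@@H](COCc2ccccc2)O[C@@H]1c1ccccc1`: "not active" (no number reported)
- compound 3, `O[C@@H]1[C@@H](OCc2ccccc2)[C@H](OCc2ccccc2)[C@@H](COCc2ccccc2)O[C@H]1c1ccccc1`: 26300 nM

In a functional assay on HL-60 cells (Homo sapiens) for antiproliferative activity, read by MTT assay (on this read-out lower numbers stand for stronger inhibition and higher numbers for weaker inhibition), compound 1 gives 39300 nM. Compound 2, in this assay, is reported as "not active" (no number reported), with no number attached. Compound 3 gives 26300 nM in this assay. The two numbers that exist, those of compound 3 and compound 1, lie within the usual scatter of each other, so the two cannot be ranked. Compound 2 and compound 3 differ only in how one ring carbon is drawn (the fact that compounds 2 and 3 differ only in the configuration as drawn), and that drawing goes together with one compound yielding a number and the other none.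

Compound 4, `CC(C)C[C@@H]1O[C@H](COCc2ccccc2)[C@@H](OCc2ccccc2)[C@H](OCc2ccccc2)[C@H]1O`, has not yet been measured. It differs from compound 3 in one place: isobutyl in place of phenyl on a saturated ring carbon. Going by the values given here, no measured pair shows what such a swap does, so there is no basis for expecting a large move in either direction. Compound 4 is therefore expected to stay close to compound 3, with the step of a 1.1-fold higher number from compound 3 to compound 4 (0.06 log units; within the scatter) estimated to lie within the scatter. The estimated value for compound 4 in this assay is 30000 nM, with a range from 10000 nM to 100000 nM.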

Compound 4, half-maximal inhibitory concentration: 8500 nM
Estimate against measurement, compound 4: 3.5-fold (0.55 log units) above; the measured number lies below the stated range.
By their numbers in this assay, from the lowest: compound 4; then compounds 3 and 1 (each within the scatter of the next).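

In this assay, the ring carbon next to the ring oxygen now has a measured change of group: isobutyl in place of phenyl comes with a 3.1-fold lower number from compound 3 to compound 4 (0.49 log units; beyond the scatter). This shows that a six-membered aromatic ring is not needed at this position for a number to be obtained, since isobutyl has no ring and compound 4 still gives a value, and that the group placed here can move the read-out beyond the usual scatter. The earlier compounds pointed to this same carbon only through its drawn configuration, which went with a number in one case and none in the other: the fact that compounds 2 and 3 differ only in the configuration as drawn

From the compounds shown here alone, a single swap cannot separate the loss of the aromatic ring from the arrival of a branched chain, and the effect of the opposite drawn configuration with isobutyl on this carbon remains unknown. Going by these compounds, how a longer straight chain, a cyclohexyl ring or an amine would behave at this position also stays open, so the direction seen here cannot yet be called a trend.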